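A few compounds are considered here, and "the series" means these few. Any claim that something is new, unique, unknown or untested is made for them only; others in the source may bear on it.

Measured compounds:
- compound 1, `COc1ccc2[nH]c(C(=O)N3CC(=O)N(Cc4ccccc4)[C@@H](CN4CCC5(CC4)CC5)C3)cc2c1`, which in a physicochemical assay for solubility, read by spectrophotometry, in phosphate buffer, with a stated time of 2 h, at pH 7.4 (a higher number here means a more soluble compound, a lower number a less soluble compound), gives 28200 nM
- compound 2, `O=C(c1cc2cc(C3CC3)ccc2[nH]1)N1CC(=O)N(Cc2ccccc2)[C@@H](CN2CCN(Cc3ccccc3)CC2)C1`, which in this assay gives 12900 nM

Compound 1 stands highest of the two numbers; its nearest neighbour, compound 2, gives a number lower by a gap that lies beyond the scatter of this kind of measurement. For the measured compounds named here, no step between two measured compounds that differ in one place has been recorded, so nothing in these two values alone says how a single change moves the read-out.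

Compound 3, `COc1ccc2[nH]c(C(=O)N3CC(=O)N(Cc4ccccc4)[C@@H](CN4C(=O)c5ccccc5C4=O)C3)cc2c1`, has not yet been measured. It differs from compound 1 in one place: a group of 11 heavy atoms (8 carbon, 1 nitrogen, 2 oxygen; one five-membered non-aromatic ring with 1 hetero atom, one six-membered aromatic ring of carbon only) in place of a group of 8 heavy atoms (7 carbon, 1 nitrogen; one three-membered non-aromatic ring of carbon only, one six-membered non-aromatic ring with 1 hetero atom), on a saturated chain carbon bound to a saturated ring carbon. Going by the values given here, with no comparable step among the measured compounds, the size of the step from compound 1 to compound 3 in this assay is not anchored by data; the step is expected to be downward, beyond the scatter, as a 5.6-fold lower number from compound 1 to compound 3 (0.75 log units; beyond the scatter). Compound 3 is therefore expected to give 5000 nM, within a range from 1500 nM to 16000 nM.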

Compound 3, solubility: > 100000 nM
Compound 3 gave a limit, no number (the forecaster's own chance of this, stated with the estimate: 10%); at least 20-fold (1.30 log units) between middle value and limit.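

In this assay compound 3 gives no number but a limit of the assay: the limit of > 100000 nM in this assay, at which 1 of the 3 values shown sits.

Putting the group with a five-membered non-aromatic ring and a six-membered aromatic ring of carbon only in place of the group with a three-membered and a six-membered non-aromatic ring, on a saturated chain carbon bound to a saturated ring carbon, gives an at least 3.5-fold higher number from compound 1 to compound 3 (0.54 log units; beyond the scatter). This is the only step shown that isolates one place, and it shows that a change here can move the read-out upward beyond the scatter, though the limit leaves the full size of the rise unknown.

As far as these compounds go, whether a carboxylic acid or a longer chain at this place would move the number the same way stays open. So does whether the same exchange would give a similar step on the core of compound 2.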